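The compounds below may be only part of what the source reports. "The series", "measured", "known", "first", "only" and "open" are said of these compounds alone.

Compound 1, `FCCOc1ccc(N2CCN(CCCCc3cn(-c4ccc(F)cc4)c4ccccc34)CC2)cc1`, gives 614 nM in an assay on brain for displacement of a labelled ligand from Sigma non-opioid intracellular receptor 1 (Rattus norvegicus); on this read-out lower numbers stand for stronger inhibition and higher numbers for weaker inhibition. Compound 2, `COc1cc2c(cc1OC)CN(CCCCn1cc(CCF)c3ccccc31)CC2`, gives 494 nM in this assay. Of the two numbers recorded, that of compound 2 is the lower one, yet its gap to compound 1 lies within the usual scatter of repeated measurements, so the two compounds cannot be told apart on this read-out. Among the compounds with values here, the two compounds also share no single point of difference, so no step between measured compounds is available to lean on.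

Compound 3, `COc1cc2c(cc1OC)CN(CCCCn1cc(CCCF)c3ccccc31)CC2`, keeps the core of compound 2 and differs from it in one place: fluoromethyl in place of fluoro on a saturated chain carbon, two bonds along the chain from an aromatic carbon. Within the data shown here, nothing among the measured compounds shows what a change of this kind does in this assay. The expectation for compound 3 is therefore a step of no clear direction from compound 2, most likely not beyond the scatter, which as a step from compound 2 to compound 3 is estimated at a 1.1-fold lower number from compound 2 to compound 3 (0.04 log units; within the scatter). For compound 3 the estimated value in this assay is 450 nM, with a range from 180 nM to 1100 nM.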

Compound 3, inhibition constant: 263 nM
Estimate against measurement, compound 3: 1.7-fold (0.23 log units) above; the measured number falls inside the stated range.
By their numbers in this assay, from the lowest: compounds 3, 2 and 1 (each within the scatter of the next, the first and the last beyond it).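

In this assay, within the data shown here, this is the first step between measured compounds, and it gives the first reading for this position: on the shared core, the exchange of 2-fluoroethyl for 3-fluoropropyl, fluoromethyl in place of fluoro on a saturated chain carbon, amounts to a 1.9-fold lower number from compound 2 to compound 3 (0.27 log units; within the scatter) and no more. The position therefore takes this longer fluorinated chain on this core without a change that can be told apart from repeat measurement, which the unrelated pair of compound 1 and compound 2 could not show. No measurement at hand offers a reason for the size of this step.

A single pair leaves open whether a longer chain such as 4-fluorobutyl, or a chain ending in a hydroxyl group or an amine instead of fluorine, would move the number beyond the scatter at this position. It also leaves open whether the same exchange would read alike on a core other than that of compound 2 and compound 3.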